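The source may report more compounds than this note shows. Statements on the series, on what has been measured and on what is new or still open speak of the compounds shown alone.

Three compounds have been measured so far in an assay on isolated protein for inhibition of Amine oxidase [flavin-containing] B (Homo sapiens), read by Amplex Red, with a stated time of 15 min; on this read-out lower numbers stand for stronger inhibition and higher numbers for weaker inhibition:

compound 1, `CC(=O)c1ccc(OCc2ccc(C)cc2)cc1`, giving 102 nM
compound 2, `CC(=O)c1ccc(OCc2ccc(C(F)(F)F)cc2)cc1`, giving 77.8 nM
compound 3, `CC(=O)c1cccc(OCc2ccc(C)cc2)c1`, giving 140 nM

Compound 1 and compound 2 share a core and differ in one place: trifluoromethyl in place of methyl on an aromatic carbon. In this assay this change made a step of a 1.3-fold lower number from compound 1 to compound 2 (0.12 log units; within the scatter), so the two values sit within the scatter of each other and no order between compound 1 and compound 2 can be read from them.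

Compound 3 has the same atoms as compound 1 joined differently; the difference between the two cores is not broken down here. Its value in this assay stands within the scatter of both compound 1 and compound 2, so nothing separates the three measured compounds on this read-out.

Compound 4, `CC(=O)c1cccc(OCc2ccc(C(F)(F)F)cc2)c1`, has not been measured in this assay. It differs from compound 3 in one place: trifluoromethyl in place of methyl on an aromatic carbon. The place is described in the same words as for the change from compound 1 to compound 2, so it is the same change on the core of compound 3.

For the measured compounds named here, the expectation for compound 4 rests on the one earlier instance of this change, the step of a 1.3-fold lower number from compound 1 to compound 2 (0.12 log units; within the scatter). Compound 4 is therefore expected to show a step of a 1.3-fold lower number from compound 3 to compound 4 (0.12 log units; within the scatter) in this assay, which would leave it within the scatter of compound 3. The estimate for compound 4 in this assay is 105 nM, between 55 nM and 210 nM.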

Compound 4, half-maximal inhibitory concentration: 43.2 nM
For compound 4 the middle estimate is 2.4-fold (0.39 log units) above the measured one, outside the stated range (below it).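

In this assay, for the compounds shown here, trifluoromethyl in place of methyl on the core of compound 3 gives a 3.2-fold lower number from compound 3 to compound 4 (0.51 log units; beyond the scatter), so on this core the change has a readable effect, whereas its one earlier instance on the core of compound 1 gave a step too small to read. This does not show that the core alters the size of the change: with only two instances, the series supports neither a larger effect on the core of compound 3 nor a size that holds fixed from core to core, and it says nothing of cores beyond these two. The two steps can be treated as one transferable change for now, since the gap between them does not exceed what repeated measurement of two such steps would produce: the same change on two cores in this assay, a 1.3-fold lower number (0.12 log units; within the scatter) from compound 1 to compound 2 and a 3.2-fold lower number (0.51 log units; beyond the scatter) from compound 3 to compound 4, 2.5-fold (0.39 log units) apart, within the scatter of two such steps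

The compounds shown leave open whether the step on the core of compound 3 belongs to trifluoromethyl alone or would also appear with a chlorine, a nitrile or a methoxy group at the same place. They also leave open how the change carries over once the acetyl group gives way to an amide or a carboxylic acid, or the ether link to a longer chain.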